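Aryl Exchange on the Ring Amine Nitrogen of Compound 2

A few compounds are considered here, and "the series" means these few. Any claim that something is new, unique, unknown or untested is made for them only; others in the source may bear on it.

Among the measured compounds shown here, compound 2 `Nc1scc(CN2CCN(c3cccc(Cl)c3Cl)CC2)c1C(=O)c1ccc(Cl)cc1` gives -77% in a functional assay on CHO cells with adenosine receptor A1 (Homo sapiens) as the target, read by cAMP accumulation and immunoassay, with a stated time of 6 min, tested at 10 uM (on this read-out lower numbers stand for a stronger effect and higher numbers for a weaker effect at the one concentration tested), the lowest of the two numbers known here. Compound 1 `CC(C)N1CCN(Cc2csc(N)c2C(=O)c2ccc(Cl)cc2)CC1` gives -7.4% in this assay, and the step of a number 69.6 percentage points lower from compound 1 to compound 2 (beyond the scatter) separates the two. Compound 3 `COc1ccc(N2CCN(Cc3csc(N)c3C(=O)c3ccc(Cl)cc3)CC2)cc1` has not yet been measured; it differs from compound 2 by 4-methoxyphenyl in place of 2,3-dichlorophenyl on an amine nitrogen in a ring. For the measured compounds named here, only one measured step bears on this change, and it concerns a different exchange on the same amine nitrogen in a ring: isopropyl replaced by 2,3-dichlorophenyl brought a large lowering. Nothing measured shows how two different aromatic groups on that nitrogen compare. The exchange of 2,3-dichlorophenyl for 4-methoxyphenyl is therefore expected to keep part of the effect but to weaken it, with an estimated step of a number 32 percentage points higher from compound 2 to compound 3 (beyond the scatter), upward and beyond the scatter. Compound 3 is expected to give about -45%, within a range from -80% to -5%.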

Compound 3, a percentage reported as activity, at one concentration (the size of the read-out at that concentration, not a potency): -52%
Beside the measured number, compound 3's estimate is 7 percentage points above it; measured number inside the range.
By their numbers in this assay, from the lowest: compound 2; then compound 3; then compound 1.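

In this assay, among the compounds shown here, 4-methoxyphenyl in place of 2,3-dichlorophenyl gives the first comparison of two aromatic groups on this amine nitrogen in a ring, with a number 25 percentage points higher from compound 2 to compound 3 (beyond the scatter), so the identity of the aromatic group changes the read-out and not only its presence. The lowering is nevertheless not confined to 2,3-dichlorophenyl, since 4-methoxyphenyl in place of isopropyl still gives a number 44.6 percentage points lower from compound 1 to compound 3 (beyond the scatter). No supporting evidence is available to explain the difference between the two aromatic groups.

On these data alone, because the chlorine atoms and the methoxy group change together here, it remains open what a plain phenyl or a 4-chlorophenyl group would give on the same nitrogen. As far as these compounds go, it also remains open whether a benzyl group or a pyridine ring there would keep the lowering.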